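Methoxy in place of hydrogen on compound 3

This account rests on a few compounds, and the source may have more. Where it says the series, first, only, none or still open, it means among the compounds named here.

In a functional assay on HepG2 cells (Homo sapiens) for inhibition, read by MTT assay, with a stated time of 72 h (a higher number here means a weaker inhibitor, a lower number a stronger inhibitor), compound 1 `COc1ccc(/C=C/C(=O)c2c(OC)cc(O)c(CC=C(C)C)c2O)cc1OC` gives 13800 nM. Compound 3 `COc1ccc(/C=C/C(=O)c2c(O)cc(O)cc2OC)cc1OC` gives 18500 nM, which is a 1.3-fold higher number from compound 1 to compound 3 (0.13 log units; within the scatter), with hydrogen in place of 3-methylbut-2-en-1-yl. For the measured compounds named here, these are the only two exact numbers, and they lie within the scatter of each other. Compound 2 `COc1cc(OC)c(OC)cc1/C=C/C(=O)c1c(OC)cc(O)c(CC=C(C)C)c1O` reads > 50000 nM, which is a limit and not a number.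

Compound 4 `COc1cc(OC)c(OC)cc1/C=C/C(=O)c1c(O)cc(O)cc1OC` carries one change from compound 3, methoxy in place of hydrogen on an aromatic carbon.

The same replacement has been measured once, and that step is an at least 3.6-fold higher number from compound 1 to compound 2 (0.55 log units; beyond the scatter). It is beyond the scatter, and its true size is open because it ends at a limit. Since the step to compound 3 stays within the scatter, compound 3 is a reasonable base on which to carry the replacement over, although a single precedent is thin support. A step of at least modest size toward a higher number is therefore expected, which would mean a weaker inhibitor. The ceiling also matters here, given (the limit of > 50000 nM in this assay, at which 1 of the 3 values shown sits), and compound 4 may well return only a limit.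

The expected change is a 2.6-fold higher number from compound 3 to compound 4 (0.41 log units; beyond the scatter). For compound 4 the estimate is 48000 nM, with an expected range of 22000 nM to 100000 nM.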

Compound 4, half-maximal inhibitory concentration: 18700 nM
For compound 4 the middle estimate is 2.6-fold (0.41 log units) above the measured one; measured number outside the range, below it.
By their numbers in this assay, from the lowest: compounds 1, 3 and 4 (each within the scatter of the next). At a limit, above all of these: compound 2.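

In this assay, methoxy in place of hydrogen on an aromatic carbon does not carry a fixed effect from one core to the other, since on the core without 3-methylbut-2-en-1-yl the result is a 1.0-fold higher number from compound 3 to compound 4 (0.00 log units; within the scatter), and the single earlier precedent did not transfer: the same change on two cores in this assay, an at least 3.6-fold higher number (0.55 log units; beyond the scatter) from compound 1 to compound 2 and a 1.0-fold higher number (0.00 log units; within the scatter) from compound 3 to compound 4, at least 3.5-fold (0.55 log units) apart, beyond the scatter of two such steps

The 3-methylbut-2-en-1-yl group also reads differently once the extra methoxy is present, with hydrogen in its place giving an at least 2.6-fold lower number from compound 2 to compound 4 (0.42 log units; beyond the scatter), whereas the same replacement without that methoxy stayed within the scatter: the same change on two cores in this assay, a 1.3-fold higher number (0.13 log units; within the scatter) from compound 1 to compound 3 and an at least 2.6-fold lower number (0.42 log units; beyond the scatter) from compound 2 to compound 4, at least 3.5-fold (0.55 log units) apart, beyond the scatter of two such steps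

For the compounds shown here, the two changes therefore do not add independently in these four compounds, and the loss seen with the added methoxy appears only in compound 2, the one compound that carries both groups.

Going by these compounds, compound 2 reads > 50000 nM, which is a limit and not a number, so the true size of both steps that touch it remains open. On these data alone, it also remains open whether this dependence on the core extends to a hydroxy group or an amine on the same aromatic carbon, or to a longer chain in place of 3-methylbut-2-en-1-yl.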